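This account rests on a few compounds, and the source may have more. Where it says the series, first, only, none or still open, it means among the compounds named here.

Compound 1 `O=C(Nc1nc(-c2ccccc2)nc2cn(-c3ccccc3)nc12)c1ccco1` carries a single (furan-2-yl)carbonyl on the amide-type nitrogen of its shared core. In an assay on CHO cells for displacement of a labelled ligand from adenosine receptor A1 (Homo sapiens), read by scintillation counting, with a stated time of 120 min, tested at 1 uM (a higher number here means more inhibition at the concentration tested (going by the name of the read-out), a lower number less inhibition), compound 1 gives 11%. For the measured compounds named here, compound 2 `COc1ccc(-n2cc3nc(-c4ccccc4)nc(N)c3n2)cc1`, which carries a free amino group on a related core, is the only other compound measured here; in this assay compound 2 gives 12%, a number that sits within the usual scatter of the value for compound 1, so the two cannot be told apart on these data. Both numbers mark only slight inhibition at the concentration tested.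

Compound 3 `O=C(c1ccco1)N(C(=O)c1ccco1)c1nc(-c2ccccc2)nc2cn(-c3ccccc3)nc12` differs from compound 1 in one place: (furan-2-yl)carbonyl in place of hydrogen on an amide-type nitrogen. The nitrogen thus carries two such carbonyl groups instead of one.

Going by the values given here, no step between measured compounds is available to calibrate what such a change does in this assay, so the expectation rests on the low values of compound 1 and compound 2 alone. On that basis the change from compound 1 to compound 3 is expected to give a step of a number 1 percentage points lower from compound 1 to compound 3 (within the scatter), not beyond the scatter in either direction. Compound 3 is therefore estimated to give 10%, with a range from 0% to 25%.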

Compound 3, a percentage reported as inhibition, at one concentration (the size of the read-out at that concentration, not a potency): 3%
For compound 3 the middle estimate is 7 percentage points above the measured one; measured number inside the range.
By their numbers in this assay, from the lowest: compounds 3, 1 and 2 (each within the scatter of the next).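

For the compounds shown here, compound 1 and compound 3 are the first pair here that differ in one place, and they give a first direct reading at the amide-type nitrogen. In this assay, (furan-2-yl)carbonyl in place of hydrogen at this position gives a number 8 percentage points lower from compound 1 to compound 3 (within the scatter) and so produces no change that can be told apart from repeat measurement, even though the amide hydrogen is lost and a second five-membered aromatic ring enters. Nothing measured on these compounds accounts for this result or says what the change does beyond the read-out itself.

With all the numbers lying so low, the data leave open whether any group on this nitrogen can raise inhibition at the concentration tested, and a fall from compound 1 would have little room to show. Going by these compounds, whether an acetyl group, a longer acyl chain or a carboxylic acid on this nitrogen would behave in the same way remains open, as does whether the phenyl groups on the shared core matter for the read-out at all.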